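A Methylsulfonylpiperazine Replaces the Hydroxypropyl Chain

This account rests on a few compounds, and the source may have more. Where it says the series, first, only, none or still open, it means among the compounds named here.

Compound 1 `COc1cc(N)c(Cl)cc1C(=O)NC1CCN(CCCCCO)CC1` is known only as a limit: in a functional assay on HEK293 cells for activation of 5-hydroxytryptamine receptor 4 (Homo sapiens), read by cAMP accumulation (a higher number here means a larger maximal response, a lower number a smaller maximal response), compound 1 gives > 100%. Compound 2 `COc1cc(N)c(Cl)cc1C(=O)NC1CCN(CCCCCN2C(=O)c3ccccc3C2=O)CC1` likewise reaches a limit, giving > 100% in this assay. For the measured compounds named here, the step that the two limits leave unreadable from compound 1 to compound 2 is therefore unreadable, and the limit of > 100% in this assay, at which 2 of the 2 values shown sit, shows that every value so far sits at that limit. Compound 3 `COc1cc(N)c(Cl)cc1C(=O)NC1CCN(CCN2CCN(S(C)(=O)=O)CC2)CC1` differs from compound 1 by 4-(methylsulfonyl)piperazin-1-yl in place of 3-hydroxypropyl on a saturated chain carbon, two bonds along the chain from an amine nitrogen in a ring. Going by the values given here, no measured step offers a readable size to lean on, so the step of a number no higher from compound 1 to compound 3 (the limit leaves the size open) is expected to be none beyond the scatter. Compound 3 is estimated to give 100%, within a range from 70% to 115%.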

Compound 3, intrinsic activity: the largest response reached, in percent of the reference agonist's: 97%
For compound 3 the middle estimate is 3 percentage points above the measured one; measured number inside the range.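

For the compounds shown here, compound 3 is the first compound here to give a number rather than a limit in this assay, so 4-(methylsulfonyl)piperazin-1-yl at this place still allows a large maximal response. The change is a number at least 3 percentage points lower from compound 1 to compound 3 (that floor lies within the scatter). Compound 1 remains a limit, so the true size of this step stays open, and the other values stay at that limit: the limit of > 100% in this assay, at which 2 of the 3 values shown sit.

On these data alone, what remains open is how a piperazine carrying an acetyl group or a carboxylic acid in place of methylsulfonyl would behave here.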